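Swapping Chloro for Fluoro on a Shared Scaffold

The compounds below may be only part of what the source reports. "The series", "measured", "known", "first", "only" and "open" are said of these compounds alone.

Of the compounds shown here, two have so far been tested in an assay on isolated protein for inhibition of glucose-6-phosphatase catalytic subunit 1 (Homo sapiens), read by inositol phosphate accumulation, with a stated time of 30 min, tested at 100 uM; a lower number here means less inhibition, a higher number more inhibition at the concentration tested (going by the name of the read-out). Compound 1 `COc1ccc(C2C=C(c3ccccc3)NC3=C2C(=O)CCC3)cc1` gives 17.3%. Compound 2 `CCOC(=O)C1=CC(c2ccc(Cl)cc2)C2=C(CC(C)(C)CC2=O)N1` gives 11.3%, the lower of the two numbers, yet compound 1 stands only a few points higher, and that gap lies within the usual scatter, so the two cannot be told apart on these numbers.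

Compound 3 `CCOC(=O)C1=CC(c2ccc(F)cc2)C2=C(CC(C)(C)CC2=O)N1` has not yet been measured. It differs from compound 2 in one place: fluoro in place of chloro on an aromatic carbon. The shared core stays untouched; only the chloro becomes fluoro.

Going by the values given here, no step between two measured compounds shows how such a change moves the numbers in this assay. One halogen in place of another at the same spot is a change of a single heavy atom, and compound 2 already shows little inhibition at 11.3%. The step from compound 2 to compound 3 is therefore expected to be a number 0.3 percentage points lower from compound 2 to compound 3 (within the scatter), no larger than the scatter and with no direction favoured. Compound 3 is estimated to give 11%, within a range from 2% to 22%.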

Compound 3, a percentage reported as inhibition, at one concentration (the size of the read-out at that concentration, not a potency): "not active" (no number reported)
The entry for compound 3 holds no number; the estimate stays without a comparison.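

In this assay, going by these compounds alone, compound 3 is reported as "not active" with no number, so no step from compound 2 to compound 3 can be read. No other data here bear on this result. The compounds shown leave open how far changing 4-chlorophenyl to 4-fluorophenyl on the shared core moves inhibition, and in which direction.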